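The compounds below may be only part of what the source reports. "The series", "measured", "known", "first", "only" and "open" are said of these compounds alone.

For the measured compounds named here, in an assay on isolated protein for activation of cGMP-dependent protein kinase 1 (Homo sapiens), read by ADP-Glo, with stated times of 120 min and 40 min (a higher number here means that more compound is needed for the effect, a lower number that less compound is needed), compound 2 `O=C(O)c1cncc(CN2CCC[C@H](OCc3cc(Cl)cc(Cl)c3)[C@@H]2c2ccccc2)c1` gives 117000 nM, the only number among the values shown. In this assay compound 1 `Clc1cc(Cl)cc(CO[C@H]2CCCN(Cc3ccccn3)[C@H]2c2ccccc2)c1` gives > 200000 nM, which is a limit rather than a number (the limit of > 200000 nM in this assay, at which 1 of the 2 values shown sits). Going by the values given here, the one measured step, an at least 1.7-fold lower number from compound 1 to compound 2 (0.23 log units; that floor lies within the scatter), changed the same position and its floor lies within the scatter. Compound 3 `Clc1cc(Cl)cc(CO[C@H]2CCCN(Cc3nccs3)[C@H]2c2ccccc2)c1` differs from compound 2 by 1,3-thiazol-2-yl in place of 5-carboxypyridin-3-yl on a saturated chain carbon bound to an amine nitrogen in a ring. Because an at least 1.7-fold lower number from compound 1 to compound 2 (0.23 log units; that floor lies within the scatter) barely moved the number, compound 3 is expected to return toward the limit, at an estimated 200000 nM, with a range from 80000 nM to 500000 nM. That expected step is a 1.7-fold higher number from compound 2 to compound 3 (0.23 log units; within the scatter).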

Compound 3, half-maximal effective concentration: > 200000 nM
Compound 3 was reported as a limit; the forecaster's own chance of this, stated with the estimate: 55%; the middle value sits exactly at the limit.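

In this assay, 1,3-thiazol-2-yl in place of 5-carboxypyridin-3-yl on a saturated chain carbon bound to an amine nitrogen in a ring gives an at least 1.7-fold higher number from compound 2 to compound 3 (0.23 log units; that floor lies within the scatter). The step between compound 1 and compound 3 cannot be read, as both values are limits. Compound 1 and compound 3, neither with a carboxylic acid, both sit at the limit: the limit of > 200000 nM in this assay, at which 2 of the 3 values shown sit.

For the compounds shown here, whether the carboxylic acid matters at all stays open, since the only readable steps lie within the scatter. An amide or an amine in its place could speak to that.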